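This account rests on a few compounds, and the source may have more. Where it says the series, first, only, none or still open, it means among the compounds named here.

Measured in an ADME assay on microsomes from liver (Mus musculus) for metabolic stability, read by LC-MS, using NADPH, with stated times of 15 min and 60 min, tested at 4.6 uM; on this read-out lower numbers stand for a shorter-lived compound and higher numbers for a longer-lived compound:
Compound 1, `CC(C)CNC(=O)n1c(=O)oc2cc(C3CCN(C)CC3)ccc21`, a limit of the assay: > 1 h.
Compound 2, `CN1CCC(c2ccc3c(c2)oc(=O)n3C(=O)NCCCCc2ccccc2)CC1=O`: 0.583 h.
Compound 3, `CCN1CCN(c2ccc3c(c2)oc(=O)n3C(=O)NCCCCc2ccccc2)CC1`, a limit of the assay: < 0.0834 h.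

Compound 3 sits at the lower limit, (the limit of < 0.0834 h in this assay, at which 1 of the 3 values shown sits); only compound 2 gives a number, and compound 1 sits at the upper limit, (the limit of > 1 h in this assay, at which 1 of the 3 values shown sits). Compound 4, `CC(=O)N1CCC(c2ccc3c(c2)oc(=O)n3C(=O)NCCCCc2ccccc2)CC1`, differs from compound 3 by 1-acetylpiperidin-4-yl in place of 4-ethylpiperazin-1-yl on an aromatic carbon. Among the compounds with values here, the one measured step bearing on this is an at least 6.9-fold lower number from compound 2 to compound 3 (0.84 log units; beyond the scatter), in which 4-ethylpiperazin-1-yl entered in place of 1-methyl-2-oxopiperidin-4-yl. Compound 4 removes that group again and brings in 1-acetylpiperidin-4-yl, a six-membered ring with one hetero atom and a double bond outside the aromatic rings, as in compound 2. A rise beyond the scatter is therefore expected, of about an at least 5.9-fold higher number from compound 3 to compound 4 (0.77 log units; beyond the scatter). Compound 4 is estimated at 0.5 h, within 0.15 h to 1.5 h.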

Compound 4, half-life: 1 h
Compound 4: middle estimate off by 2.0-fold (0.30 log units), on the low side, and the stated range covers the measured number.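

In this assay, 1-acetylpiperidin-4-yl on this aromatic carbon gives an at least 11-fold higher number from compound 3 to compound 4 (1.07 log units; beyond the scatter), so a second replacement of 4-ethylpiperazin-1-yl now yields a large step. Compound 3 stands at a limit of the assay: the limit of < 0.0834 h in this assay, at which 1 of the 4 values shown sits. The two carbonyl-bearing piperidine groups are not separated here: a 1.7-fold higher number from compound 2 to compound 4 (0.23 log units; within the scatter).

As far as these compounds go, whether the step follows the second ring nitrogen, the ethyl group or the carbonyl stays open. A 1-ethylpiperidin-4-yl or 4-acetylpiperazin-1-yl group at this position would separate these.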